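Moving the methyl group of compound 3

The source may report more compounds than this note shows. Statements on the series, on what has been measured and on what is new or still open speak of the compounds shown alone.

In a functional assay on A-431 cells (Homo sapiens) for cytotoxicity (a lower number here means that less compound is needed, a higher number that more compound is needed for the effect), compound 1 (`COC1=C(C)C(=O)/C(=C(O)/C=C/c2ccc(OC)cc2)C(=O)C1(C)C`) gives 9.2 ug/mL, compound 2 (`COC1=C(C)C(=O)/C(=C(O)/C=C/c2ccc(O)cc2)C(=O)C1(C)C`) gives 14.9 ug/mL and compound 3 (`COC1=C(C)C(=O)/C(=C(O)/C=C/c2ccc(C)cc2)C(=O)C1(C)C`) gives 5.1 ug/mL. Compound 3 thus stands at the low end of these numbers. The data show a 1.8-fold lower number from compound 1 to compound 3 (0.26 log units; within the scatter), so that gap gives no order, whereas a 2.9-fold lower number from compound 2 to compound 3 (0.47 log units; beyond the scatter) is a modest separation.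

Compound 4 (`COC1=C(C)C(=O)/C(=C(O)/C=C/c2ccccc2C)C(=O)C1(C)C`) has the same atoms joined differently, with 2-methylphenyl in place of 4-methylphenyl on a double-bonded chain carbon bound to a double-bonded chain carbon. Among the measured compounds shown here, no measured step moves a group on the aromatic ring, so the three steps bear on this change only indirectly. They exchange one group for another, and the largest, a 2.9-fold lower number from compound 2 to compound 3 (0.47 log units; beyond the scatter), is modest, while a 1.6-fold higher number from compound 1 to compound 2 (0.21 log units; within the scatter) stays within the scatter. Nothing beyond the scatter is therefore expected in this assay, and the expected step is a 1.3-fold higher number from compound 3 to compound 4 (0.11 log units; within the scatter). Compound 4 is estimated at 6.5 ug/mL, with an expected range of 3.2 ug/mL to 13 ug/mL.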

Compound 4, concentration for half-maximal effect: 5.2 ug/mL
For compound 4 the middle estimate is 1.3-fold (0.10 log units) above the measured one; low and high end bracket the measured number.
By their numbers in this assay, from the lowest: compounds 3, 4, 1 and 2 (each within the scatter of the next, the first and the last beyond it).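

In this assay, among the compounds shown here, the first step that moves a group on the aromatic ring, 2-methylphenyl in place of 4-methylphenyl, gives a 1.0-fold higher number from compound 3 to compound 4 (0.01 log units; within the scatter) and so does not separate the two methylphenyl groups at this place. Compound 4 also keeps the relation that compound 3 had to the other two compounds: a 2.9-fold lower number from compound 2 to compound 4 (0.46 log units; beyond the scatter) is a modest separation, while a 1.8-fold lower number from compound 1 to compound 4 (0.25 log units; within the scatter) gives no order. Nothing available here explains this result.

The compounds shown leave open whether an amine, a carboxylic acid or a longer chain in place of this methyl would keep the number at this level. They also leave open whether moving the hydroxy group of compound 2 or the methoxy group of compound 1 around the aromatic ring would change its number.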